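This account rests on a few compounds, and the source may have more. Where it says the series, first, only, none or still open, it means among the compounds named here.

Measured so far in this set:

compound 1 `COc1ccc(-c2ccc3c(NCCCNCc4cccc(OC)c4O)ccnc3c2)cc1` — 237 10^-6 cm/s
compound 2 `CC(C)(C)c1ccc(Oc2ccc3c(NCCCNCc4ccco4)ccnc3c2)cc1` — 317 10^-6 cm/s

In an ADME assay for permeability, using PAMPA, with a stated time of 30 min, at pH 7.4 (a higher number here means that the compound crosses the layer faster, a lower number that the compound crosses the layer more slowly), compound 1 gives 237 10^-6 cm/s. Compound 2 gives 317 10^-6 cm/s in this assay, and the gap between the two numbers is within the usual scatter of repeated measurements, so compound 1 is not separated from compound 2 on this read-out; the two values stand together.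

Compound 3 `COc1cccc(CNCCCNc2ccnc3cc(-c4ccc(C(C)(C)C)cc4)ccc23)c1O` is the next point. Relative to compound 1 the change is tert-butyl in place of methoxy on an aromatic carbon. Both measured compounds already sit in a high range of apparent permeability, and compound 2 carries the same tert-butyl on its outer phenyl ring.

For the measured compounds named here, no measured pair shows this exact step, so the expectation rests on the two values alone. The step of a 1.2-fold higher number from compound 1 to compound 3 (0.09 log units; within the scatter) is expected to be small, upward if anything, and not beyond the scatter, because compound 2 with the same tert-butyl gives 317 10^-6 cm/s in this assay. For compound 3 the expected value in this assay is 290 10^-6 cm/s, with a range from 180 10^-6 cm/s to 450 10^-6 cm/s.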

Compound 3, apparent permeability: 237 10^-6 cm/s
Beside the measured number, compound 3's estimate is 1.2-fold (0.09 log units) above it; measured number inside the range.
By their numbers in this assay, from the lowest: compounds 1, 3 and 2 (each within the scatter of the next).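

In this assay, for the compounds shown here, going from 4-methoxyphenyl to 4-(tert-butyl)phenyl on the shared core gives no change at the digits printed from compound 1 to compound 3 (within the scatter), and this is the first comparison in the set that isolates one place, as compound 1 and compound 2 differ in more than one. At this position, a group of 4 heavy atoms with 0 hydrogen-bond acceptors replaces one of 2 heavy atoms with 1 hydrogen-bond acceptor, and the read-out stays where it was, so this change carries no visible penalty or gain here. No measurement in hand explains this flat result.

Going by these compounds alone, this single step covers only two groups at one place, so it remains open whether an amine, a carboxylic acid or a nitrile at the same aromatic carbon would leave the read-out equally undisturbed. On these data alone, compound 2 differs from compound 3 in more than one place, so the effect of a longer chain or of other changes away from this aromatic carbon remains open in this assay as well.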